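Tetrazole series: from amide to urea at compound 3

A few compounds are considered here, and "the series" means these few. Any claim that something is new, unique, unknown or untested is made for them only; others in the source may bear on it.

Measured in a functional assay on NCI-H460 cells (Homo sapiens) for positive allosteric modulation, read by MTT assay, with stated times of 2 h and 72 h, tested at 1 uM; a higher number here means a weaker inhibitor, a lower number a stronger inhibitor:
Compound 1 `COc1ccc(C(=O)Nc2ccccc2-c2nnn(-c3ccc(OC)cc3)n2)cc1` gives 305 nM
Compound 2 `COc1cccc(-n2nnc(-c3ccccc3NC(=O)c3ccc(NC(=O)CBr)cc3)n2)c1` gives 241 nM

Compound 1 and compound 2 lie within the scatter of each other, so the two numbers set no order. Compound 3 `COc1ccc(NC(=O)Nc2ccccc2-c2nnn(-c3ccc(OC)cc3)n2)cc1` is not yet measured. Its change from compound 1 is (4-methoxyphenyl)amino in place of 4-methoxyphenyl on a carbonyl carbon. Within the data shown here, no measured pair shows a single change, so the size of this step is open. No step beyond the scatter is expected in this assay, and no direction is firmly expected. The estimated 1.1-fold higher number from compound 1 to compound 3 (0.06 log units; within the scatter) is small. For compound 3 the estimated value is 350 nM, with an expected range from 100 nM to 1200 nM.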

Compound 3, half-maximal inhibitory concentration: 255 nM
Compound 3: the middle estimate sits 1.4-fold (0.14 log units) above what was measured; measured number inside the range.
By their numbers in this assay, from the lowest: compounds 2, 3 and 1 (each within the scatter of the next).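

In this assay, among these compounds, this is the first pair that differs in one place, and it gives a 1.2-fold lower number from compound 1 to compound 3 (0.08 log units; within the scatter). On a carbonyl carbon whose other neighbour is an amide-type nitrogen, (4-methoxyphenyl)amino can therefore stand in place of 4-methoxyphenyl, and the added hydrogen-bond donor comes with no step beyond the scatter. Nothing at hand explains this result.

Still open, on these data alone, is whether the entering nitrogen can carry a methyl group or give way to a methylene or an oxygen atom. No step beyond the scatter has yet appeared at this place among the compounds shown.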